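Working notes: dichlorophenyl analogue of compound 2

The compounds below may be only part of what the source reports. "The series", "measured", "known", "first", "only" and "open" are said of these compounds alone.

The series is read in an assay on isolated protein for inhibition of malate dehydrogenase, mitochondrial (Sus scrofa), with stated times of 45 min and 30 min; on this read-out lower numbers stand for stronger inhibition and higher numbers for weaker inhibition. Compound 2 `O=S(=O)(Nc1ccc2oc(-c3ccccc3)nc2c1)c1cccc(F)c1` gives only a limit in this assay, > 63000 nM. Compound 1 `O=S(=O)(Nc1ccc(-c2nc3ccccc3o2)cc1)c1ccc(Cl)c(C(F)(F)F)c1` likewise stops at the limit, > 63000 nM. Compound 3 `O=S(=O)(Nc1ccc(-c2nc3ccccc3o2)cc1)c1ccc(F)cc1` also returns no number but the limit, > 63000 nM. All three results therefore sit together on (the limit of > 63000 nM in this assay, at which 3 of the 3 values shown sit), and no number separates any two of them; on the values shown, compound 2 stands with the others at the limit, with nothing to rank it against either of them.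

Compound 4 `O=S(=O)(Nc1ccc2oc(-c3ccccc3)nc2c1)c1ccc(Cl)c(Cl)c1` is not yet measured in this assay. It differs from compound 2 in one place: 3,4-dichlorophenyl in place of 3-fluorophenyl on a sulfonyl sulfur. Among the compounds with values here, no pair of measured compounds shows a step in this assay, so there is no measured step to lean on. Within the data shown here, the only pointer is compound 1, which also carries chlorine on the ring bound to the sulfonyl sulfur and reaches only the limit, > 63000 nM. The expected step from compound 2 to compound 4 is therefore a step that the limit leaves unreadable from compound 2 to compound 4, none beyond the scatter. For compound 4 the estimate is 80000 nM, in a range from 25000 nM to 250000 nM, and most probably the assay will again report only a limit.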

Compound 4, half-maximal inhibitory concentration: > 63000 nM
Compound 4 gave a limit, no number; the forecaster's own chance of this, stated with the estimate: 80%; the middle value is on the limit's open side.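

Compound 4 returns only a limit, as compound 2 does, so no step can be read between compound 2 and compound 4 in this assay: the limit of > 63000 nM in this assay, at which 4 of the 4 values shown sit.

The compounds shown leave open whether any change on the shared core would give a number rather than a limit in this assay, and so how 3,4-dichlorophenyl and 3-fluorophenyl compare.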